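Enlarging the fluoro substituent of compound 1

The compounds below may be only part of what the source reports. "The series", "measured", "known", "first", "only" and "open" are said of these compounds alone.

Compound 1 `Fc1cccc(-c2cn([C@@H]3CN4CCC3CC4)nn2)c1`: 2.25 nM
Compound 2 `Fc1cccc(-c2cn(C3CN4CCC3CC4)nn2)c1`: 5.24 nM
Compound 3 `Fc1ccc(-c2cn([C@@H]3CN4CCC3CC4)nn2)cc1`: 3.09 nM

These numbers come from an assay on HEK293 cells for displacement of a labelled ligand from Neuronal acetylcholine receptor; alpha3/beta4 (Homo sapiens), read by scintillation counting, with a stated time of 120 min; a lower number here means a stronger inhibitor, a higher number a weaker inhibitor. Compound 1 has the lowest number of the three; compound 3 sits within the scatter of it, while compound 2 lies beyond, a step of a 2.3-fold higher number from compound 1 to compound 2 (0.37 log units; beyond the scatter) that may be connected with the fact that one of compounds 1 and 2 is drawn with a defined configuration and the other without, at the place where they differ. Compound 4 `Fc1ccc(COc2cccc(-c3cn([C@@H]4CN5CCC4CC5)nn3)c2)cc1` keeps the shared core but differs in one place: (4-fluorobenzyl)oxy in place of fluoro on an aromatic carbon, that is, a (4-fluorobenzyl)oxy group on an aromatic carbon of a six-membered aromatic ring of carbon only, meta to a large group. For the measured compounds named here, none of the measured steps involves a change of this kind; the only step beyond the scatter concerns stereochemistry. The expectation for compound 4 in this assay is therefore loosely held, a modest weakening, a 3.6-fold higher number from compound 1 to compound 4 (0.55 log units; beyond the scatter). Compound 4 is estimated at 8 nM, within a range from 1.5 nM to 50 nM.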

Compound 4, inhibition constant: 7.17 nM
The estimate for compound 4 lay 1.1-fold (0.05 log units) above the measured number, and the stated range covers the measured number.
By their numbers in this assay, from the lowest: compounds 1, 3, 2 and 4 (each within the scatter of the next, the first and the last beyond it).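

For the compounds shown here, replacing fluoro with (4-fluorobenzyl)oxy on this aromatic carbon gives a 3.2-fold higher number from compound 1 to compound 4 (0.50 log units; beyond the scatter) in this assay and so extends what the earlier compounds showed, since they carried only fluoro on this ring. A group of 9 heavy atoms with its own aromatic ring is accepted here at a modest cost, with compound 4 still at 7.17 nM as its measured number. Nothing measured here explains this step. Open, from the compounds shown here alone, is whether the oxygen or the added ring drives the step, and whether a smaller methoxy group, an amine or a carboxylic acid at this place would behave alike.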